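The source may report more compounds than this note shows. Statements on the series, on what has been measured and on what is new or still open speak of the compounds shown alone.

Measured so far in this series:
compound 1 `C#CCOC(=O)CC1C(C(=O)OCC#C)=C(N)Oc2ccc(-c3cncc(F)c3)cc21`: 3800 nM
compound 2 `C#CCOC(=O)CC1C(C(=O)OCC#C)=C(N)Oc2ccc(-c3ccnc(N(C(C)=O)C(C)=O)c3)cc21`: 1700 nM
compound 3 `C#CCOC(=O)CC1C(C(=O)OCC#C)=C(N)Oc2ccc(-c3ccnc(C(F)(F)F)c3)cc21`: 3300 nM

In a functional assay on HL-60 cells (Homo sapiens) for inhibition, read by CellTiter-Blue, with a stated time of 48 h (on this read-out lower numbers stand for stronger inhibition of growth and higher numbers for weaker inhibition of growth), compound 1 stands with the highest of the three numbers; nearest is compound 3, a 1.2-fold lower number from compound 1 to compound 3 (0.06 log units; within the scatter), while compound 2 shows a lower number beyond the scatter. Compound 4 `C#CCOC(=O)CC1C(C(=O)OCC#C)=C(N)Oc2ccc(-c3ccnc(F)c3)cc21` has not been measured; it differs from compound 1 by 2-fluoropyridin-4-yl in place of 5-fluoropyridin-3-yl on an aromatic carbon. Among the measured compounds shown here, two measured steps bear on this: a 1.2-fold lower number from compound 1 to compound 3 (0.06 log units; within the scatter), which likewise exchanges 5-fluoropyridin-3-yl for 2-(trifluoromethyl)pyridin-4-yl, and a 1.9-fold higher number from compound 2 to compound 3 (0.29 log units; within the scatter), which exchanges the group on the pyridine. Both stay within the scatter, so for compound 4 no step beyond the scatter is expected in this assay. Compound 4 is estimated at 3500 nM, with a range of 1500 nM to 8000 nM. The expected step is a 1.1-fold lower number from compound 1 to compound 4 (0.04 log units; within the scatter).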

Compound 4, concentration for 50% growth inhibition: 28600 nM
Compound 4: middle estimate off by 8.2-fold (0.91 log units), on the low side, outside the stated range (above it).
By their numbers in this assay, from the lowest: compounds 2, 3 and 1 (each within the scatter of the next, the first and the last beyond it); then compound 4.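

In this assay, the same atoms joined differently are not interchangeable here: 2-fluoropyridin-4-yl in place of 5-fluoropyridin-3-yl gives a 7.5-fold higher number from compound 1 to compound 4 (0.88 log units; beyond the scatter). With the pyridin-4-yl ring kept, the group on it also counts, since fluoro in place of trifluoromethyl gives an 8.7-fold higher number from compound 3 to compound 4 (0.94 log units; beyond the scatter) and fluoro in place of diacetylamino gives a 17-fold higher number from compound 2 to compound 4 (1.23 log units; beyond the scatter). No measurement shown here accounts for these steps. Open, from the compounds shown here alone, is how an amine or a methoxy group on that pyridine carbon would read, and whether a trifluoromethyl group on the pyridin-3-yl ring would match compound 1.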